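Adding a methyl to compound 1

A few compounds are considered here, and "the series" means these few. Any claim that something is new, unique, unknown or untested is made for them only; others in the source may bear on it.

In a functional assay on HL-60 cells (Homo sapiens) for inhibition, read by CCK-8 assay, with a stated time of 48 h (on this read-out higher numbers stand for weaker inhibition and lower numbers for stronger inhibition), compound 1 `O=C(NCCNS(=O)(=O)c1sccc1-c1ccccc1Oc1ccc(O)c(O)c1)Nc1cc(Cl)cc(Cl)c1` gives 6900 nM. Compound 3 `CC(C)c1ccc(Oc2ccc(O)c(O)c2)c(-c2ccsc2S(=O)(=O)NCCNC(=O)Nc2cc(Cl)cc(Cl)c2)c1` gives 6500 nM and compound 2 `O=[N+]([O-])c1ccc(NC(=S)NCCNS(=O)(=O)c2ccc(-c3ccccc3OCc3cccc(O)c3)s2)cc1` gives 10800 nM. Both lie within the scatter of compound 1, so compound 1 holds no distinct place on these numbers.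

The next structure is compound 4 `Cc1ccc(-c2ccsc2S(=O)(=O)NCCNC(=O)Nc2cc(Cl)cc(Cl)c2)c(Oc2ccc(O)c(O)c2)c1`. The change is methyl in place of hydrogen on an aromatic carbon, meta to a 3,4-dihydroxyphenoxy group and para to a large group.

Among the measured compounds shown here, only one measured step bears on this change: a 1.1-fold lower number from compound 1 to compound 3 (0.03 log units; within the scatter), with isopropyl in place of hydrogen on an aromatic carbon. That substitution, a larger group than methyl, leaves the number within the scatter. For the measured compounds named here, it is indirect evidence, however, as it does not sit on the same carbon and no measured compound carries a methyl. Going by the values given here, compound 2 differs from compound 1 in more than one place and supplies no single-change step.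

In this assay, no shift beyond the scatter is therefore expected, and no direction can be assigned. The estimated step is a 1.1-fold lower number from compound 1 to compound 4 (0.03 log units; within the scatter). Compound 4 is estimated at 6500 nM, with an expected range of 3500 nM to 12000 nM.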

Compound 4, half-maximal inhibitory concentration: 3500 nM
For compound 4 the middle estimate is 1.9-fold (0.27 log units) above the measured one, within the range that was stated.
By their numbers in this assay, from the lowest: compounds 4, 3, 1 and 2 (each within the scatter of the next, the first and the last beyond it).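

In this assay, a methyl in place of hydrogen on this aromatic carbon, meta to a 3,4-dihydroxyphenoxy group and para to a large group, gives a 2.0-fold lower number from compound 1 to compound 4 (0.29 log units; within the scatter). Among the compounds shown here, this is the first direct reading at this carbon, and it shows that a methyl here leaves the number within the scatter, whereas the earlier isopropyl step, a 1.1-fold lower number from compound 1 to compound 3 (0.03 log units; within the scatter), was on a different carbon and could bear on this position only indirectly. Both single substitutions on this six-membered ring therefore stay within the scatter of compound 1, and nothing available explains the size or direction of the methyl step.

The compounds shown leave open whether any group on this carbon moves the number beyond the scatter, since methyl is the only group shown here and an amine, a carboxylic acid or a longer chain such as n-propyl could behave differently. They also leave open whether isopropyl on this same carbon would give a result like that of the methyl, which would separate the effect of the position from that of the group.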